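One double bond, drawn two ways

The compounds below may be only part of what the source reports. "The series", "measured", "known", "first", "only" and "open" are said of these compounds alone.

Measured values in a physicochemical assay for lipophilicity (a higher number here means a more lipophilic compound, a lower number a more polar compound), are as follows.

- compound 1 `CCCCCCCC(=O)/C(C)=C(/C)C(=O)O` gives 2.4
- compound 2 `COC(=O)/C=C/C(=O)c1ccccc1` gives 2.24
- compound 3 `C/C(=C/C(=O)c1ccc(C)cc1)C(=O)O` gives 2.19

Compound 3 lies within the scatter of both compound 2 and compound 1, so these three values cannot be ranked. Compound 4 `C/C(=C\C(=O)c1ccc(C)cc1)C(=O)O` has not yet been measured, and its relation to compound 3 is simple: the two compounds have the same atoms and bonds and differ only in configuration as drawn: 1 of 1 stereo elements differ; a double bond is drawn Z in compound 3 and E in compound 4. A double bond is drawn Z in compound 3 and E in compound 4. Going by the values given here, no measured pair shows what such a change does, so the expectation rests on compound 3 at 2.19 alone. In this assay the expected result is a number 0.01 log units higher from compound 3 to compound 4 (within the scatter) with no move in either direction beyond the scatter. Compound 4 is estimated at 2.2 with an expected range from 1.9 to 2.5 in this measurement.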

Compound 4, partition coefficient: 2.94
The estimate for compound 4 lay 0.74 log units below the measured number, and the stated range ends below it.
By their numbers in this assay, from the lowest: compounds 3, 2 and 1 (each within the scatter of the next); then compound 4.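

In this assay, the configuration of this double bond alone carries a real step, a number 0.75 log units higher from compound 3 to compound 4 (beyond the scatter), something compound 1, compound 2 and compound 3 could not show, as no two of them differ in one place. The step belongs to the double bond, because nothing else separates the pair: the fact that compounds 3 and 4 differ only in the configuration as drawn

The compounds shown leave open whether a step of this size would survive with an amide in place of the carboxylic acid. With a single pair, they also cannot say whether this change behaves alike on any other core.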